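This account rests on a few compounds, and the source may have more. Where it says the series, first, only, none or still open, it means among the compounds named here.

Measured so far in a physicochemical assay for solubility; on this read-out lower numbers stand for lower solubility and higher numbers for higher solubility:
- Compound 1 `CNC(=O)c1cc(C(=O)NC2CCOCC2)cn(Cc2ccccc2)c1=O`: >= 174 ug/mL (a limit)
- Compound 2 `CNC(=O)c1cccn(Cc2ccccc2)c1=O`: 78 ug/mL
- Compound 3 `CNC(=O)c1cc(C(=O)NCCO)cn(Cc2ccccc2)c1=O`: >= 140 ug/mL (a limit)

In this assay compound 3 gives no exact number, only the limit >= 140 ug/mL. Compound 4 `CNC(=O)c1cc(C(=O)NCCOC)cn(Cc2ccccc2)c1=O` turns its 2-hydroxyethyl into 2-methoxyethyl: methyl in place of hydrogen on an oxygen on a saturated carbon.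

Among the compounds with values here, no measured step makes this exchange, so the evidence is indirect. Replacing the (oxan-4-yl)carbamoyl with hydrogen gave an at least 2.2-fold lower number from compound 1 to compound 2 (0.34 log units; beyond the scatter). Putting (2-hydroxyethyl)carbamoyl in place of that hydrogen gave an at least 1.7-fold higher number from compound 2 to compound 3 (0.25 log units; that floor lies within the scatter). Exchanging the two side chains themselves gave a step that the two limits leave unreadable from compound 1 to compound 3. Both amide-bearing compounds thus end at limits, and neither of them can show how far a small change on the side chain moves the number.

In this assay the expected step is a step that the limit leaves unreadable from compound 3 to compound 4, which means none beyond the scatter. Compound 4 is estimated at 150 ug/mL, with an expected range from 90 ug/mL to 220 ug/mL.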

Compound 4, solubility: >= 164 ug/mL
Compound 4 gave a limit, no number; the forecaster's own chance of this, stated with the estimate: 60%; middle value at least 1.0-fold (0.03 log units) from the limit.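

Methyl in place of hydrogen on an oxygen on a saturated carbon still leaves the read-out at a limit: in this assay, compound 4 gives >= 164 ug/mL, which is a limit and not a number. Against the unsubstituted compound, the 2-methoxyethyl side chain gives an at least 2.1-fold higher number from compound 2 to compound 4 (0.32 log units; beyond the scatter), so this amide clears the scatter, whereas the floor of an at least 1.7-fold higher number from compound 2 to compound 3 (0.25 log units; that floor lies within the scatter) did not. The steps to compound 4 from compound 3 and from compound 1 cannot be read, as both ends of each are limits.

On these data alone, how far compound 1, compound 3 and compound 4 each lie past their limits stays open, and with it any order among the three side chains. Also open, as far as these compounds go, is what a longer chain or an amine in place of the 2-methoxyethyl would give in this assay.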